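From Acetamido to Amino on a Single Nitrogen

The compounds below may be only part of what the source reports. "The series", "measured", "known", "first", "only" and "open" are said of these compounds alone.

In a functional assay on HepG2 cells (Homo sapiens) for cytotoxicity, read by sulforhodamine B assay, with a stated time of 48 h (on this read-out lower numbers stand for stronger inhibition and higher numbers for weaker inhibition), compound 1 (`COc1ccc(/C=C/C(=O)c2ccc(NC(C)=O)c(-c3ccc(F)cc3)c2)cc1OC`) gives 5630 nM and stands with compound 2 (`COc1cc(/C=C/C(=O)c2cccc(-c3cccc(F)c3)c2)ccc1O`), whose 6830 nM lies within the usual scatter of it. Together these two form the higher end of the three numbers so far. Compound 3 (`COc1ccc(/C=C/C(=O)c2cccc(-c3cccc(F)c3)c2)cc1`) reads 1720 nM as a lower number, and its gap to compound 1 lies beyond the scatter.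

Compound 4 (`COc1ccc(/C=C/C(=O)c2ccc(N)c(-c3ccc(F)cc3)c2)cc1OC`) has not yet been measured. It carries hydrogen in place of acetyl on a nitrogen on an aromatic ring, the change from acetamido to amino (hydrogen in place of acetyl on a nitrogen on an aromatic ring) on the core of compound 1. For the measured compounds named here, no measured pair shows this change on its own, and neither compound 2 nor compound 3 has such a nitrogen, so the data offer no direct guide. The measured compounds do stay fairly close together, running from compound 3 at 1720 nM to compound 2 at 6830 nM in the same read-out. A small step in this assay is therefore expected, leaning slightly towards a lower number and not clearly beyond the scatter. The estimated step of a 1.4-fold lower number from compound 1 to compound 4 (0.15 log units; within the scatter) is offered with that caution. For compound 4 the estimate is 4000 nM with an expected range from 1500 nM to 10000 nM as its bounds.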

Compound 4, half-maximal inhibitory concentration: 3780 nM
Compound 4: middle estimate off by 1.1-fold (0.02 log units), on the high side, and the stated range covers the measured number.
By their numbers in this assay, from the lowest: compound 3; then compounds 4, 1 and 2 (each within the scatter of the next).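

This first matched pair isolates the nitrogen on an aromatic ring: with the rest of the core of compound 1 unchanged, hydrogen in place of acetyl gives a 1.5-fold lower number from compound 1 to compound 4 (0.17 log units; within the scatter) in this assay. For the compounds shown here, the acetamido and amino forms therefore read alike here, so the acetyl, with its 3 heavy atoms and its hydrogen-bond acceptor, can be absent from this nitrogen without a difference beyond the scatter, something no earlier compound could show, since neither compound 2 nor compound 3 has such a nitrogen. No independent measurement bears on this result, so the pair records the size of the step and offers no explanation for it.

The compounds shown leave open whether a longer acyl chain such as butanoyl, a methanesulfonyl group or a dimethylamino group on this same nitrogen would also read alike, or would separate from the acetamido and amino forms. Going by these compounds alone, they also leave open whether the change from acetamido to amino would give a similarly small step on any core other than that of compound 1, as this single pair is the only instance of it.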